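A few compounds are considered here, and "the series" means these few. Any claim that something is new, unique, unknown or untested is made for them only; others in the source may bear on it.

Compound 1 `COc1ccc(/C=C/C(=O)c2sc(Nc3ccc(Cl)cc3)nc2C)cc1`: in a functional assay on NCI-H460 cells (Homo sapiens) for cytotoxicity, read by MTT assay (on this read-out lower numbers stand for stronger inhibition and higher numbers for weaker inhibition), compound 1 gives > 25000 nM, which is a limit of the assay and not a number.
Compound 2 `Cc1nc(Nc2ccc(Cl)cc2)sc1C(=O)/C=C/c1ccc(Cl)cc1`: in this assay compound 2 gives > 25000 nM, again only a limit.
Compound 3 `Cc1nc(Nc2ccc(Cl)c(Cl)c2)sc1C(=O)/C=C/c1ccc(Cl)cc1`: in this assay compound 3 gives > 25000 nM, again only a limit.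

The change from compound 2 to compound 1 is methoxy in place of chloro on an aromatic carbon; it made a step that the two limits leave unreadable from compound 2 to compound 1. The cores of compound 2 and compound 3 differ by chloro in place of hydrogen on an aromatic carbon, which made a step that the two limits leave unreadable from compound 2 to compound 3. Compound 4 `COc1ccc(/C=C/C(=O)c2sc(Nc3ccc(Cl)c(Cl)c3)nc2C)cc1` carries the same change on the core of compound 3: methoxy in place of chloro on an aromatic carbon, at a place described in the same words as before. Because (the limit of > 25000 nM in this assay, at which 3 of the 3 values shown sit), no size can be read from the measured step, and compound 4 is expected to remain at that limit, the estimated step being a step that the limit leaves unreadable from compound 3 to compound 4. The estimate for compound 4 is 40000 nM, expected to fall between 20000 nM and 100000 nM.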

Compound 4, half-maximal inhibitory concentration: > 25000 nM
Compound 4 gave a limit, no number; the forecaster's own chance of this, stated with the estimate: 85%; the middle value is on the limit's open side.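

No new step can be read from compound 4 or its pairs with compound 1 and compound 3, as each value is only a limit: the limit of > 25000 nM in this assay, at which 4 of the 4 values shown sit. The compounds shown leave open how 4-chlorophenyl and 4-methoxyphenyl compare on this core.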